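Second chloro on the aryl group of compound 1

The source may report more compounds than this note shows. Statements on the series, on what has been measured and on what is new or still open speak of the compounds shown alone.

Compound 1 `O=CN1CCN(c2ccc(Cl)cc2)C1=S` and compound 2 `O=CN1CCN(C(=O)c2ccco2)C1=S` share a core and have both been examined in a functional assay on T47D cells (Homo sapiens) for inhibition, read by sulforhodamine B assay, with a stated time of 48 h; on this read-out lower numbers stand for stronger inhibition of growth and higher numbers for weaker inhibition of growth. Compound 1 gives 12800 nM, the higher of the two numbers. Compound 2 gives 4000 nM, the nearer and only other value, and the gap between the two lies beyond the usual scatter. Among the measured compounds shown here, no pair of measured compounds differs in one place only, so the effect of changing a single aromatic substituent on this core is not established from these two. Compound 3 `O=CN1CCN(c2ccc(Cl)c(Cl)c2)C1=S` differs from compound 1 by chloro in place of hydrogen on an aromatic carbon. For the measured compounds named here, with no comparable measured step, a step of modest size in this assay is expected from compound 1 to compound 3, toward a lower number if anything, and it may lie within the scatter. Compound 3 is therefore estimated at 9000 nM, with a range of 3000 nM to 30000 nM. The step this estimate implies is a 1.4-fold lower number from compound 1 to compound 3 (0.15 log units; within the scatter).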

Compound 3, concentration for 50% growth inhibition: 15300 nM
Estimate against measurement, compound 3: 1.7-fold (0.23 log units) below; the measured number falls inside the stated range.
By their numbers in this assay, from the lowest: compound 2; then compounds 1 and 3 (each within the scatter of the next).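

In this assay, chloro in place of hydrogen gives a 1.2-fold higher number from compound 1 to compound 3 (0.08 log units; within the scatter), the first single-place step available on this core. At this aromatic carbon, ortho to a chloro group and meta to a group of 8 heavy atoms, the added chlorine therefore produces no difference that can be told from repeat measurement, a reading that holds for this one pair only. No measurement is at hand that bears on why this step is so small.

As far as these compounds go, it remains open whether a different group on the same carbon, such as an amine, a methoxy group or a carboxylic acid, would shift the number beyond the scatter. Also open, from the compounds shown here alone, is what happens on the shared core when the chloro group of compound 1 gives way to hydrogen or to a longer chain.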